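A few compounds are considered here, and "the series" means these few. Any claim that something is new, unique, unknown or untested is made for them only; others in the source may bear on it.

Three compounds have been measured in an ADME assay on microsomes from liver (Rattus norvegicus) for metabolic stability; a higher number here means that the compound lasts longer, a lower number that the compound disappears faster:

Compound 1 `COc1cc(OCc2csc(-c3ccc(C(C)(C)O)cc3)n2)c2cc(-c3cn4nc(OC)sc4n3)oc2c1` gives 1.15 h
Compound 2 `COc1cc(OCc2cccc(-c3ccc(C#N)cn3)c2)c2cc(-c3cn4nc(OC)sc4n3)oc2c1` gives 0.833 h
Compound 3 `CNC(=O)c1ccc(-c2nc(COc3cc(OC)cc4oc(-c5cn6nc(OC)sc6n5)cc34)cs2)cc1` gives 0.517 h

Among these three numbers, compound 3 has the lowest. Its gap to compound 2 is within the scatter, so the two cannot be told apart on this evidence. For the measured compounds named here, its gap to compound 1 is larger and is the one measured step in this set: a 2.2-fold lower number from compound 1 to compound 3 (0.35 log units; beyond the scatter). Going by the values given here, that step is also the only comparison that touches the group at this end of the molecule.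

Compound 4 `COc1cc(OCc2csc(-c3ccc(C(=O)O)cc3)n2)c2cc(-c3cn4nc(OC)sc4n3)oc2c1` differs from compound 3 in one place: hydroxy in place of methylamino on a carbonyl carbon. Seen one bond further out, this reads as methylcarbamoyl becoming carboxy. Among the compounds with values here, no measured pair exchanges an amide for an acid, so the step from compound 1 to compound 3 bears on it only loosely; it shows that altering this group moved the number modestly, not greatly. For compound 4 the expectation in this assay is therefore a step no larger than the scatter, in no firm direction. Compound 4 is estimated at 0.6 h, with a range from 0.3 h to 1.3 h. That estimate amounts to an expected step of a 1.2-fold higher number from compound 3 to compound 4 (0.06 log units; within the scatter).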

Compound 4, half-life: > 2 h
Compound 4 ended at the assay's limit; the forecaster's own chance of this, stated with the estimate: 5%; at least 3.3-fold (0.52 log units) between middle value and limit.
By their numbers in this assay, from the lowest: compounds 3, 2 and 1 (each within the scatter of the next, the first and the last beyond it). At a limit, above all of these: compound 4.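

In this assay compound 4 gives > 2 h, which is a limit of the assay and not a measured number: the limit of > 2 h in this assay, at which 1 of the 4 values shown sits. Even so, putting hydroxy in place of methylamino on the carbonyl carbon, which turns methylcarbamoyl into carboxy, gives an at least 3.8-fold higher number from compound 3 to compound 4 (0.58 log units; beyond the scatter), so this small exchange at the end of the molecule clearly matters; the earlier step, a 2.2-fold lower number from compound 1 to compound 3 (0.35 log units; beyond the scatter), had shown only that one replacement here could lower the number. The comparison with the 1-hydroxy-1-methylethyl group is less firm, at an at least 1.7-fold higher number from compound 1 to compound 4 (0.24 log units; that floor lies within the scatter), so carboxy cannot yet be placed clearly ahead of that group.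

The compounds shown leave open how long compound 4 actually lasts, since only its limit is available. They also leave open whether a methyl ester or a primary amide on the same aromatic carbon would track carboxy or methylcarbamoyl, which would help show whether the gain belongs to the carboxylic acid itself or simply to the loss of the methylamino group.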